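The compounds below may be only part of what the source reports. "The series", "measured", "known", "first", "only" and "open" are said of these compounds alone.

Measured compounds:
- compound 1, `O=C(Nc1ccccc1C(F)(F)F)C1CCc2ccccc2N1C(=O)c1cccc(Cl)c1`: 526 nM
- compound 2, `COc1ccc(NC(=O)C2CCc3ccccc3N2)cc1`: 38000 nM
- compound 3, `O=C(Nc1cc(C(F)(F)F)cc(C(F)(F)F)c1)C1CCc2ccccc2N1C(=O)c1ccc(Cl)cc1`: 2570 nM

In a functional assay on ACHN cells (Homo sapiens) for cytotoxicity, read by sulforhodamine B assay, with a stated time of 72 h (on this read-out lower numbers stand for stronger inhibition of growth and higher numbers for weaker inhibition of growth), compound 1 gives 526 nM, the lowest of the three numbers. Compound 3 gives 2570 nM, a higher number that lies beyond the scatter, and compound 2 gives 38000 nM, the highest number by a wide margin. Among the measured compounds shown here, no pair of measured compounds differs in a single place, so no direct step between them can be read off.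

Compound 4, `O=C(Nc1ccccc1C(F)(F)F)C1CCc2ccccc2N1`, is compound 1 with one change: hydrogen in place of (3-chlorophenyl)carbonyl on a nitrogen on an aromatic ring in a ring. Only compound 2 among the measured compounds carries hydrogen on that ring nitrogen, and compound 2 is the weakest; but compound 2 also differs from compound 1 in its amide partner, so the two values only hint at what the change does. Still, that hint points one way: the expected step of a 29-fold higher number from compound 1 to compound 4 (1.46 log units; beyond the scatter) is a large rise in number, well beyond the scatter. Compound 4 is therefore estimated at 15000 nM, within a range of 3000 nM to 60000 nM.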

Compound 4, concentration for 50% growth inhibition: 57600 nM
Beside the measured number, compound 4's estimate is 3.8-fold (0.58 log units) below it, and the stated range covers the measured number.
By their numbers in this assay, from the lowest: compound 1; then compound 3; then compounds 2 and 4 (each within the scatter of the next).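

In this assay hydrogen in place of (3-chlorophenyl)carbonyl on the ring nitrogen gives a 110-fold higher number from compound 1 to compound 4 (2.04 log units; beyond the scatter) and so measures this change directly, with the amide partner held the same. Among the compounds shown here, the step is large and lies beyond the scatter, so growth inhibition at the level of compound 1 depends heavily on what sits on this nitrogen, which the earlier compounds could only hint at. No measurement shown explains why the group matters so much.

From the compounds shown here alone, only these two ends of the range appear at this position, so it remains open whether an acetyl group, a methyl group or a benzoyl group without chlorine would keep any of the growth inhibition. Going by these compounds, it is also open whether a step of this size would recur with a different amide partner.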